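The source may report more compounds than this note shows. Statements on the series, on what has been measured and on what is new or still open speak of the compounds shown alone.

Compound 1 `Cc1cc(C)n2nccc2n1`: 65 mg/kg
Compound 2 `Cc1cc(C)n2ncc(Br)c2n1`: 18.4 mg/kg

In a functional assay on the whole organism with Rattus norvegicus as the target (on this read-out lower numbers stand for an effect already at smaller amounts and higher numbers for an effect only at larger amounts of compound), compound 2 gives 18.4 mg/kg, the lowest of the two numbers, and compound 1 gives 65 mg/kg. Compound 3 `Cc1cc(C)n2ncc(I)c2n1` differs from compound 2 by iodo in place of bromo on an aromatic carbon. For the measured compounds named here, the only measured step, a 3.5-fold lower number from compound 1 to compound 2 (0.55 log units; beyond the scatter), put bromo in place of hydrogen; no measured step swaps one halogen for another, so that step bears only loosely on this change. The step expected from it is a 1.2-fold lower number from compound 2 to compound 3 (0.09 log units; within the scatter), small and within the scatter, leaning toward a lower number. For compound 3 the estimated value is 15 mg/kg, with a range from 7 mg/kg to 35 mg/kg.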

Compound 3, dose for half-maximal effect: 19.8 mg/kg
The estimate for compound 3 lay 1.3-fold (0.12 log units) below the measured number; the range from low to high includes it.
By their numbers in this assay, from the lowest: compounds 2 and 3 (each within the scatter of the next); then compound 1.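

In this assay the step is a 1.1-fold higher number from compound 2 to compound 3 (0.03 log units; within the scatter) and so gives no sign that iodo and bromo differ at this position. Iodo in place of hydrogen gives a 3.3-fold lower number from compound 1 to compound 3 (0.52 log units; beyond the scatter) and stays beyond the scatter, so a lower number at this aromatic carbon now appears with two halogens, not just with bromo. Nothing measured here accounts for this result. On these data alone, whether chloro or fluoro would behave like these two halogens remains open. So does the outcome with a non-halogen group on this carbon, such as an amine or a longer chain.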